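Fluorine on the Pendant Phenyl of a Sulfonamide Analogue

The source may report more compounds than this note shows. Statements on the series, on what has been measured and on what is new or still open speak of the compounds shown alone.

Compound 3 `CS(=O)(=O)c1ccc(C2=NN(c3ccc(S(N)(=O)=O)cc3)C(c3ccccc3)C2)cc1` has been run in a functional assay on the whole organism for inhibition, with Rattus norvegicus as the target, read by paw edema, with a stated time of 3 h, at a dose of 50 mg/kg by the oral route (a higher number here means more inhibition at the dose given (going by the name of the read-out), a lower number less inhibition), where compound 3 gives 54.3%. Among the three measured compounds this number is the second highest: compound 1 `CS(=O)(=O)c1ccc(C2=NN(c3ccc(C(=O)O)cc3)C(c3ccccc3)C2)cc1` gives 56.4%, with the step of a number 2.1 percentage points lower from compound 1 to compound 3 (within the scatter) lying within the scatter, while compound 2 `CS(=O)(=O)c1ccc(C2=NN(c3ccc(C(=O)O)cc3)C(c3ccc(F)cc3)C2)cc1` gives 42.3%. Compound 4 `CS(=O)(=O)c1ccc(C2=NN(c3ccc(S(N)(=O)=O)cc3)C(c3ccc(F)cc3)C2)cc1` is not yet measured; it differs from compound 3 by fluoro in place of hydrogen on an aromatic carbon. Among the measured compounds shown here, the one measured step of the same kind is a number 14.1 percentage points lower from compound 1 to compound 2 (beyond the scatter), a drop beyond the scatter. The same change made on compound 3 is therefore expected to lower the number by a comparable amount, a number 13.3 percentage points lower from compound 3 to compound 4 (beyond the scatter). Compound 4 is accordingly estimated at 41%, within a range from 30% to 52%.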

Compound 4, a percentage reported as inhibition, in the whole organism at one dose (the size of the read-out at that dose, not a potency): 65.7%
Compound 4: middle estimate off by 24.7 percentage points, on the low side; the measured number lies above the stated range.
By their numbers in this assay, from the lowest: compound 2; then compounds 3, 1 and 4 (each within the scatter of the next, the first and the last beyond it).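

In this assay the fluoro group gives a number 11.4 percentage points higher from compound 3 to compound 4 (beyond the scatter), so phenyl to 4-fluorophenyl raises the number on the sulfamoyl core, where on the carboxy core it lowered it. Sulfamoyl in place of carboxy, which changed nothing beyond the scatter on the unfluorinated pair, gives a number 23.4 percentage points higher from compound 2 to compound 4 (beyond the scatter) with fluoro present, so the two changes do not act independently: the same change on two cores in this assay, a number 2.1 percentage points lower (within the scatter) from compound 1 to compound 3 and a number 23.4 percentage points higher (beyond the scatter) from compound 2 to compound 4, 25.5 percentage points apart, beyond the scatter of two such steps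

The compounds shown leave open whether chloro or methoxy in place of fluoro would split the same way between the two cores. They also leave open how these numbers would move at other doses.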